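Lengthening Methoxy to Ethoxy

A few compounds are considered here, and "the series" means these few. Any claim that something is new, unique, unknown or untested is made for them only; others in the source may bear on it.

In a functional assay on KB cells (Homo sapiens) for antiproliferative activity, read by sulforhodamine B assay, with a stated time of 72 h (a higher number here means a weaker inhibitor, a lower number a stronger inhibitor), compound 1 `O=C(/C=C/c1csc2ccccc12)c1cc(F)ccc1O` gives 7400 nM, while compound 2 `COc1ccc(O)c(C(=O)/C=C/c2csc3ccccc23)c1` gives 640 nM, the lower and so the stronger of the two numbers. Among the measured compounds shown here, the only measured step is a 12-fold lower number from compound 1 to compound 2 (1.06 log units; beyond the scatter), a large one, made by putting methoxy in place of fluoro on an aromatic carbon. Compound 3 `CCOc1ccc(O)c(C(=O)/C=C/c2csc3ccccc23)c1` differs from compound 2 by one small change: methyl in place of hydrogen on a saturated chain carbon bound to an oxygen on an aromatic ring. This is methyl in place of hydrogen on a saturated chain carbon bound to an oxygen on an aromatic ring, turning methoxy into ethoxy. For the measured compounds named here, the measured step swaps a different pair of groups, so it offers only a loose guide, and no measured pair tests a longer chain. No clear direction is therefore expected in this assay, and a change within the scatter seems likeliest. The expected step is a 1.1-fold higher number from compound 2 to compound 3 (0.04 log units; within the scatter). For compound 3 the estimated value is 700 nM, with an expected range from 250 nM to 2000 nM.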

Compound 3, half-maximal inhibitory concentration: 5800 nM
For compound 3 the middle estimate is 8.3-fold (0.92 log units) below the measured one, outside the stated range (above it).
By their numbers in this assay, from the lowest: compound 2; then compounds 3 and 1 (each within the scatter of the next).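

In this assay, the added methyl is no silent change: a 9.1-fold higher number from compound 2 to compound 3 (0.96 log units; beyond the scatter) shows that this position responds to a single extra carbon, so methoxy and ethoxy cannot be treated as interchangeable here. With a 1.3-fold lower number from compound 1 to compound 3 (0.11 log units; within the scatter), which lies within the scatter, ethoxy and fluoro cannot be told apart, so among these three compounds the lower number belongs to methoxy alone and not to oxygen-linked chains in general. Nothing measured here explains why one methyl makes so large a difference.

On these data alone, whether a longer chain such as propoxy would raise the number further or leave it unchanged remains open. So does whether a smaller group such as hydroxy, or an amine, at this place would match methoxy.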